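Amide Substituent Swap in a Weakly Inhibiting Series

The compounds below may be only part of what the source reports. "The series", "measured", "known", "first", "only" and "open" are said of these compounds alone.

Among the compounds with values here, compound 2 `CN1CCC(NC(=O)c2ccncc2Nc2cc(-c3ccc4ccn(C)c4c3)c3nccnc3c2)CC1=O` gives 48800 nM in an assay on lysate for inhibition of 6-phosphofructo-2-kinase/fructose-2,6-bisphosphatase 3 (Homo sapiens), with stated times of 0.5 min and 45 min (a higher number here means a weaker inhibitor, a lower number a stronger inhibitor), the only number among the values shown. Compound 1 `CN(C)C(=O)c1ccncc1Nc1cc(-c2ccc3ccn(C)c3c2)c2nccnc2c1` reaches only a limit in this assay, at > 100000 nM (the limit of > 100000 nM in this assay, at which 1 of the 2 values shown sits). Within the data shown here, the step of an at least 2.0-fold lower number from compound 1 to compound 2 (0.31 log units; beyond the scatter) is the sole measured step, and it runs from a limit. Compound 3 `CC(=O)N1CCOC(CNC(=O)c2ccncc2Nc2cc(-c3ccc4ccn(C)c4c3)c3nccnc3c2)C1` is related to compound 2 by (4-acetylmorpholin-2-yl)methyl in place of 1-methyl-2-oxopiperidin-4-yl on an amide-type nitrogen. Among the measured compounds shown here, since both groups sit on the same amide nitrogen and the one step gives only a lower bound, compound 3 is expected to show a 1.1-fold lower number from compound 2 to compound 3 (0.04 log units; within the scatter), no change beyond the scatter. The estimated value of compound 3 is 45000 nM, expected between 12000 nM and 160000 nM.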

Compound 3, half-maximal inhibitory concentration: > 100000 nM
Compound 3: no number, only a limit; the forecaster's own chance of this, stated with the estimate: 35%; middle value at least 2.2-fold (0.34 log units) away from the limit.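

Placing (4-acetylmorpholin-2-yl)methyl in place of 1-methyl-2-oxopiperidin-4-yl on the amide-type nitrogen gives an at least 2.0-fold higher number from compound 2 to compound 3 (0.31 log units; beyond the scatter) in this assay and shows that a six-membered non-aromatic ring on this nitrogen does not by itself keep a measurable number. Compound 3 reaches only a limit, as compound 1 does, and the step between these two limits cannot be read: the limit of > 100000 nM in this assay, at which 2 of the 3 values shown sit.

The compounds shown leave open whether a piperidine with a free ring amine or a carboxylic acid on this amide nitrogen would give a lower number than compound 2 does.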